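The compounds below may be only part of what the source reports. "The series", "measured", "known", "first", "only" and "open" are said of these compounds alone.

Values in an ADME assay on S9 fraction from liver (Rattus norvegicus) for metabolic stability, read by LC-MS, using NADPH, with a stated time of 60 min, tested at 10 uM; on this read-out higher numbers stand for a more stable compound and lower numbers for a less stable compound

compound 1 `C[C@H](O)Cc1cc(-c2ccnc3[nH]nc(C(F)(F)F)c23)cc(C2(C#N)CC2)c1` gives 37%
compound 2 `CCC(O)Cc1cc(-c2ccnc3[nH]nc(C(F)(F)F)c23)cc(C2(C#N)CC2)c1` gives 17%
compound 3 `N#CC1(c2cc(CC(O)C3CC3)cc(-c3ccnc4[nH]nc(C(F)(F)F)c34)c2)CC1` gives 0%

Compound 3 stands lowest of the three, and its gaps to both others lie beyond the scatter. The next structure is compound 4 `N#CC1(c2cc(CC(O)C(F)(F)F)cc(-c3ccnc4[nH]nc(C(F)(F)F)c34)c2)CC1`, which differs from compound 3 as follows: trifluoromethyl in place of cyclopropyl on a saturated chain carbon bound to an oxygen on a saturated carbon and a saturated chain carbon. In short, trifluoromethyl stands in place of cyclopropyl on a saturated chain carbon bound to an oxygen on a saturated carbon and a saturated chain carbon.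

Among the compounds with values here, three measured steps concern this same part of the chain. They are the modest a number 20 percentage points lower from compound 1 to compound 2 (beyond the scatter), the modest a number 17 percentage points lower from compound 2 to compound 3 (beyond the scatter) and the large a number 37 percentage points lower from compound 1 to compound 3 (beyond the scatter). None of these compounds carries trifluoromethyl, so they give only a rough guide to size. With compound 3 at 0% in this assay, there is no room for a lower number. An upward move of large size is expected, estimated as a number 40 percentage points higher from compound 3 to compound 4 (beyond the scatter). For compound 4 the estimated value is 40%, with an expected range from 15% to 70%.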

Compound 4, percent of the compound remaining: 71%
For compound 4 the middle estimate is 31 percentage points below the measured one; measured number outside the range, above it.
By their numbers in this assay, from the lowest: compound 3; then compound 2; then compound 1; then compound 4.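

In this assay, earlier changes at this position only lowered the number as the group grew from the methyl of 1-hydroxyethyl to ethyl and cyclopropyl, whereas trifluoromethyl reverses that direction, with a number 71 percentage points higher from compound 3 to compound 4 (beyond the scatter) and a number 54 percentage points higher from compound 2 to compound 4 (beyond the scatter). The 2,2,2-trifluoro-1-hydroxyethyl group also surpasses 1-hydroxyethyl, with a number 34 percentage points higher from compound 1 to compound 4 (beyond the scatter), so compound 4 goes against the earlier link between a larger group and a lower number, and group size alone does not set the order in this series. No measurement shown accounts for this rise.

Going by these compounds, whether difluoromethyl or pentafluoroethyl would hold the same position in the order remains open. Also open, on these data alone, is whether the gain in compound 4 persists when a methoxy group replaces the hydroxyl, or depends on the configuration at the carbon bearing the oxygen.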